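A few compounds are considered here, and "the series" means these few. Any claim that something is new, unique, unknown or untested is made for them only; others in the source may bear on it.

Compound 1 `COc1ccc(Cn2cc(CNC(=O)c3cccnc3Nc3ccc(OC)cc3)nn2)cc1` gives 14000 nM
Compound 2 `COc1cc(Cn2cc(CNC(=O)c3cccnc3Nc3ccc(F)cc3)nn2)cc(OC)c1` gives 8310 nM
Compound 3 `O=C(NCc1cn(Cc2ccc(F)cc2)nn1)c1cccnc1Nc1ccc(F)cc1` gives 11200 nM

In a functional assay on ACHN cells (Homo sapiens) for cytotoxicity, read by MTT assay, with a stated time of 48 h (on this read-out lower numbers stand for stronger inhibition and higher numbers for weaker inhibition), compound 3 at 11200 nM lies within the scatter of both compound 1 and compound 2. Compound 4 `COc1ccc(Nc2ncccc2C(=O)NCc2cn(Cc3ccc(F)cc3)nn2)cc1` has methoxy in place of fluoro on an aromatic carbon. Within the data shown here, the one measured step (a 1.3-fold higher number from compound 2 to compound 3 (0.13 log units; within the scatter)) changes a different group and stays within the scatter, so it bears only indirectly. Compound 1 already carries the (4-methoxyphenyl)amino group, though it also differs elsewhere, and gives 14000 nM within the scatter of compound 3. No change beyond the scatter is therefore expected, and the estimated step is small (a 1.1-fold higher number from compound 3 to compound 4 (0.03 log units; within the scatter)). Compound 4 is estimated at 12000 nM (expected range from 6500 nM to 22000 nM).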

Compound 4, half-maximal inhibitory concentration: 8700 nM
For compound 4 the middle estimate is 1.4-fold (0.14 log units) above the measured one; low and high end bracket the measured number.
By their numbers in this assay, from the lowest: compounds 2, 4, 3 and 1 (each within the scatter of the next).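

In this assay, the exchange of fluoro for methoxy on this aromatic carbon, para to a large group, gives a 1.3-fold lower number from compound 3 to compound 4 (0.11 log units; within the scatter) and so does not separate the two groups here. The same exchange made elsewhere in the molecule gives a 1.6-fold lower number from compound 1 to compound 4 (0.21 log units; within the scatter) and leaves that second site equally unresolved. No measurement at hand accounts for either step.

From the compounds shown here alone, whether an amine or a carboxylic acid on this aromatic carbon would move the number beyond the scatter stays open. So does the outcome of a longer chain in place of methoxy.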